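A few compounds are considered here, and "the series" means these few. Any claim that something is new, unique, unknown or untested is made for them only; others in the source may bear on it.

Compound 1 has the structure `Nc1nc(NC2CCCCC2)c2ncn(/C=C3/CC3(CO)CO)c2n1`. In an ADME assay on HFF cells (Homo sapiens) for cytotoxicity, with a stated time of 8 days (a lower number here means that less compound is tolerated, a higher number that more compound is tolerated), compound 1 gives > 300000 nM, which is a limit of the assay rather than a measured number. Compound 2, with the structure `Nc1nc(OCC(F)(F)F)c2ncn(/C=C3/CC3(CO)CO)c2n1`, gives > 300000 nM in this assay, again only a limit. Compound 3, with the structure `Nc1nc(N2CCCC2)c2ncn(/C=C3/CC3(CO)CO)c2n1`, gives > 300000 nM in this assay, also a limit. Because (the limit of > 300000 nM in this assay, at which 3 of the 3 values shown sit), none of the changes among these three could be sized: a step that the two limits leave unreadable from compound 1 to compound 2, a step that the two limits leave unreadable from compound 1 to compound 3 and a step that the two limits leave unreadable from compound 2 to compound 3. Compound 4 has the structure `CSc1nc(N)nc2c1ncn2/C=C1/CC1(CO)CO`. It differs from compound 1 as follows: methylsulfanyl in place of cyclohexylamino on an aromatic carbon. Among the measured compounds shown here, the steps that bear on this change are the three just named, and every one of them was left unreadable by the limits, so no step beyond the usual scatter is expected in this assay. The expected step is a number no higher from compound 1 to compound 4 (the limit leaves the size open). Compound 4 is therefore estimated to give 300000 nM in this assay, within a range from 100000 nM to 1000000 nM, and most likely the assay will once more report only a limit.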

Compound 4, half-maximal cytotoxic concentration: > 300000 nM
Compound 4 was reported as a limit (the forecaster's own chance of this, stated with the estimate: 85%); the middle value sits exactly at the limit.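

No step can be read between compound 4 and compound 1, compound 2 or compound 3, since each of these results is only a limit: the limit of > 300000 nM in this assay, at which 4 of the 4 values shown sit.

The compounds shown leave open whether swapping the group at this place on the shared core changes the result in this assay at all.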